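Compound 4: a new aryl group on the ring nitrogen

A few compounds are considered here, and "the series" means these few. Any claim that something is new, unique, unknown or untested is made for them only; others in the source may bear on it.

Measured in a functional assay on CHO cells with adenosine receptor A1 (Homo sapiens) as the target, read by cAMP accumulation and immunoassay, with a stated time of 6 min, tested at 10 uM; on this read-out lower numbers stand for a stronger effect and higher numbers for a weaker effect at the one concentration tested:
compound 1 `Nc1scc(CN2CCN(c3ccc(Cl)cc3Cl)CC2)c1C(=O)c1ccc(Cl)cc1` gives -74%
compound 2 `Nc1scc(CN2CCN(c3ccc(F)cc3Cl)CC2)c1C(=O)c1ccc(Cl)cc1` gives -70%
compound 3 `Nc1scc(CN2CCN(c3ccc([N+](=O)[O-])cc3)CC2)c1C(=O)c1ccc(Cl)cc1` gives -17%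

Compound 3 stands highest of the three numbers, set apart by the large steps of a number 57 percentage points higher from compound 1 to compound 3 (beyond the scatter) and a number 53 percentage points higher from compound 2 to compound 3 (beyond the scatter), whereas a number 4 percentage points higher from compound 1 to compound 2 (within the scatter) shows the two halogenated aryl groups giving close numbers. Compound 4 `Nc1scc(CN2CCN(c3ccccc3C(F)(F)F)CC2)c1C(=O)c1ccc(Cl)cc1` differs from compound 3 in one place: 2-(trifluoromethyl)phenyl in place of 4-nitrophenyl on an amine nitrogen in a ring. Going by the values given here, no measured step exchanges a 4-nitrophenyl for a 2-(trifluoromethyl)phenyl, so the expectation rests only on the two large steps that moved the number far down when the 4-nitrophenyl was exchanged. A downward step is therefore expected, a number 33 percentage points lower from compound 3 to compound 4 (beyond the scatter), with wide uncertainty. Compound 4 is estimated at -50%, between -80% and -15%.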

Compound 4, a percentage reported as activity, at one concentration (the size of the read-out at that concentration, not a potency): -60%
Compound 4: middle estimate off by 10 percentage points, on the high side, within the range that was stated.
By their numbers in this assay, from the lowest: compounds 1, 2 and 4 (each within the scatter of the next, the first and the last beyond it); then compound 3.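

Chloro on the aryl group is thus not required for a low number on this amine nitrogen: in this assay 2-(trifluoromethyl)phenyl in place of 4-nitrophenyl gives a number 43 percentage points lower from compound 3 to compound 4 (beyond the scatter) and brings the number back towards those of the chlorinated aryl groups. Against these groups it gives a number 10 percentage points higher from compound 2 to compound 4 (within the scatter) but also a number 14 percentage points higher from compound 1 to compound 4 (beyond the scatter) and so matches one and not the other. Nothing available explains these steps.

Going by these compounds, what a plain phenyl or a 2-methoxyphenyl would give on this nitrogen stays open, as does whether the nitro group itself or its place on the ring sets compound 3 apart.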